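A Methoxy Group Added to an Adenosine Receptor Ligand

The compounds below may be only part of what the source reports. "The series", "measured", "known", "first", "only" and "open" are said of these compounds alone.

Of the compounds shown here, two have so far been tested in an assay on CHO cells for displacement of a labelled ligand from adenosine receptor A3 (Homo sapiens), read by scintillation counting, with a stated time of 60 min, tested at 1 uM; on this read-out lower numbers stand for less inhibition and higher numbers for more inhibition at the one concentration tested (going by the name of the read-out). Compound 1 `Cn1cc2nc(-c3ccccc3)[nH]c(=O)c2n1` gives 20% in this assay, the higher of the two numbers. Compound 2 `Nc1nc(-c2ccccc2)nc2nn(-c3ccccc3)nc12` gives 1% in this assay, a number that stands well below that of compound 1, beyond the usual scatter of repeated measurements. Compound 3 `COc1ccc(-c2nc3cn(C)nc3c(=O)[nH]2)cc1`, which has not yet been measured, differs from compound 1 in one place: methoxy in place of hydrogen on an aromatic carbon The entering group sits para to a large group on the six-membered aromatic ring of carbon only. Because compound 1 reaches only 20%, a single added methoxy is not expected to move the reading far in either direction. The step of a number 2 percentage points higher from compound 1 to compound 3 (within the scatter) is expected to fall within or only just beyond the usual scatter. Compound 3 is therefore estimated at 22%, with a range from 5% to 45%.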

Compound 3, a percentage reported as inhibition, at one concentration (the size of the read-out at that concentration, not a potency): 1%
For compound 3 the middle estimate is 21 percentage points above the measured one, and the stated range ends above it.
By their numbers in this assay, from the lowest: compounds 2 and 3 (each within the scatter of the next); then compound 1.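

In this assay, methoxy in place of hydrogen on an aromatic carbon, para to a large group, gives a number 19 percentage points lower from compound 1 to compound 3 (beyond the scatter). This shows that the position is not indifferent to what sits on it, even in a compound whose reading is modest to begin with: here the hydrogen goes with more inhibition at the one concentration tested than the methoxy does. Nothing measured here explains why the reading falls.

The compounds shown leave open whether this loss belongs to methoxy in particular or would follow any group placed on this carbon. A hydroxyl, a chlorine atom, an amine or a longer chain such as ethoxy at the same place would help separate these possibilities.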